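This account rests on a few compounds, and the source may have more. Where it says the series, first, only, none or still open, it means among the compounds named here.

Of the compounds shown here, three have been measured in a functional assay on CHO cells for agonist activity at 5-hydroxytryptamine receptor 4 (Homo sapiens), read by a luciferase reporter and cAMP accumulation, with a stated time of 4 h; a lower number here means that less compound is needed, a higher number that more compound is needed for the effect. Compound 1, `COCCCN1CCC(O)(CNC(=O)c2nc(C(C)C)n3ccccc23)CC1`, gives 316 nM in this assay. Compound 2, `CCN1CCC(NC(=O)c2nc(C(C)C)n3ccccc23)CC1`, gives 50 nM. Compound 3, `CC(C)c1nc(C(=O)NC[C@@H]2[C@H]3CN(CC4CCC4)C[C@@H]23)c2ccccn12`, gives 13.2 nM, the lowest of the three numbers; compound 2 stands nearest to it, yet beyond the usual scatter, and compound 1 lies further away still. No two of these compounds differ in only one place, so none of the gaps between them can be tied to a single structural change.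

Compound 4, `CC(C)c1nc(C(=O)NC[C@@H]2[C@H]3CN(C4CCC4)C[C@@H]23)c2ccccn12`, has not yet been measured. It differs from compound 3 in one place: cyclobutyl in place of cyclobutylmethyl on an amine nitrogen in a ring, with everything else unchanged. Among the compounds with values here, with no measured pair showing a change of this kind, the expectation is a step that stays within the scatter of repeated measurements, with no clear direction. For compound 4 the expected value in this assay is therefore 15 nM, with a range from 5 nM to 45 nM. This estimate means an expected step of a 1.1-fold higher number from compound 3 to compound 4 (0.06 log units; within the scatter).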

Compound 4, half-maximal effective concentration: 18 nM
Beside the measured number, compound 4's estimate is 1.2-fold (0.08 log units) below it; measured number inside the range.
By their numbers in this assay, from the lowest: compounds 3 and 4 (each within the scatter of the next); then compound 2; then compound 1.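

This is the only pair shown that differs in one place, so a gap in this assay can for once be tied to a single structural change. On the amine nitrogen of the five-membered non-aromatic ring, the step of a 1.4-fold higher number from compound 3 to compound 4 (0.13 log units; within the scatter) means that cyclobutylmethyl and cyclobutyl, with 5 and 4 heavy atoms and the same four-membered carbon ring, cannot be told apart here. Within the data shown here, nothing measured so far gives a reason for this.

From the compounds shown here alone, both groups are carbon-only rings, so it remains open whether a phenyl ring, a benzyl group or a chain ending in a hydroxyl group on this nitrogen would also give a similar number. Going by these compounds, it is also open whether the same swap would read alike on the cores of compound 1 or compound 2, which carry other groups on their ring nitrogen.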